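Working notes on a chloro-to-trifluoromethyl exchange

The compounds below may be only part of what the source reports. "The series", "measured", "known", "first", "only" and "open" are said of these compounds alone.

Measured so far: compound 1, `CC(=O)n1nc(C)c(-c2ccc(Cl)c(Cl)c2)c1N`; compound 2, `CC(=O)n1nc(C)c(-c2cccc(Cl)c2)c1N`. Not yet measured: compound 3, `CC(=O)n1nc(C)c(-c2cccc(C(F)(F)F)c2)c1N`.

In an assay on Sf9 cells for inhibition of mitogen-activated protein kinase kinase kinase 14 (Homo sapiens), read by ADP-Glo, with a stated time of 60 min (on this read-out lower numbers stand for stronger inhibition and higher numbers for weaker inhibition), compound 1 gives 8400 nM. Compound 2 reaches only the limit of this assay, > 100000 nM, which is a limit and not a number. Compound 2 therefore stands at the weak end of what this assay resolves, far from compound 1. Within the data shown here, the single measured step, an at least 11-fold higher number from compound 1 to compound 2 (1.07 log units; beyond the scatter), removes one chloro from a six-membered aromatic ring of carbon only; its full size is not known because compound 2 sits at the limit of > 100000 nM in this assay, at which 1 of the 2 values shown sits.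

Compound 3 differs from compound 2 by trifluoromethyl in place of chloro on an aromatic carbon. Among the measured compounds shown here, no measured step exchanges chloro for trifluoromethyl, so the step from compound 1 to compound 2 bears on it only by showing where compound 2 lies. With one limit value as the starting point, a step in this assay beyond the scatter cannot be resolved in either direction, and compound 3 is expected to stay near the limit: a number no higher from compound 2 to compound 3 (the limit leaves the size open) is the estimated step. Compound 3 is expected at 100000 nM in this assay, with a range from 30000 nM to 300000 nM, and a sizeable chance that only a limit is reported again.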

Compound 3, half-maximal inhibitory concentration: > 100000 nM
Compound 3 gave a limit, no number; the forecaster's own chance of this, stated with the estimate: 65%; the middle value lies on the limit itself.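

In this assay compound 3 gives > 100000 nM, which is a limit and not a number. No step can be read from compound 2 to compound 3, because both stand at the same limit: the limit of > 100000 nM in this assay, at which 2 of the 3 values shown sit. The compounds shown leave open whether trifluoromethyl in place of chloro on an aromatic carbon changes the read-out at all, and in which direction.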